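Swapping the aryl on the triazole of a weakly active spiro core

A few compounds are considered here, and "the series" means these few. Any claim that something is new, unique, unknown or untested is made for them only; others in the source may bear on it.

Within the data shown here, compound 3 `N#CC1=C(N)Oc2c(c3nc4ccccc4nc3c3ccccc23)C12C(=O)N(Cc1cnnn1-c1cccc(S(N)(=O)=O)c1)c1ccccc12` is the one member of this small set with a measured number in a functional assay on MCF7 cells (Homo sapiens) for antiproliferative activity, read by MTT assay, with a stated time of 48 h; a higher number here means a weaker inhibitor, a lower number a stronger inhibitor: compound 3 gives 42500 nM. Its two companions share the same core and differ only in the aryl on the triazole nitrogen. Compound 1 `CCOc1ccc(-n2nncc2CN2C(=O)C3(C(C#N)=C(N)Oc4c3c3nc5ccccc5nc3c3ccccc43)c3ccccc32)cc1` returns only a limit of the assay, > 50000 nM. Compound 2 `CC(=O)Nc1ccc(-n2nncc2CN2C(=O)C3(C(C#N)=C(N)Oc4c3c3nc5ccccc5nc3c3ccccc43)c3ccccc32)cc1` likewise returns only a limit, > 50000 nM. The step of an at least 1.1-fold lower number from compound 1 to compound 3 (0.07 log units; that floor lies within the scatter) and the step of an at least 1.1-fold lower number from compound 2 to compound 3 (0.07 log units; that floor lies within the scatter) therefore cannot be read as more than a floor, and the step that the two limits leave unreadable from compound 1 to compound 2 cannot be read at all, because the limit of > 50000 nM in this assay, at which 2 of the 3 values shown sit, holds two of the three values.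

Compound 4 `N#CC1=C(N)Oc2c(c3nc4ccccc4nc3c3ccccc23)C12C(=O)N(Cc1cnnn1-c1ccc(Cl)c(Cl)c1)c1ccccc12` changes the same position again: 3,4-dichlorophenyl in place of 3-sulfamoylphenyl on an aromatic nitrogen. The measured steps that bear on this are the two aryl swaps into compound 3, both at the floor and within the scatter, so no step beyond the scatter is expected in this assay, in either direction. The expected step of a 1.1-fold lower number from compound 3 to compound 4 (0.03 log units; within the scatter) is thus essentially flat. Compound 4 is estimated at 40000 nM, with a range from 12000 nM to 120000 nM, and a real chance that only a limit is returned.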

Compound 4, half-maximal inhibitory concentration: > 50000 nM
Compound 4 was reported as a limit (the forecaster's own chance of this, stated with the estimate: 40%); at least 1.2-fold (0.09 log units) between middle value and limit.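

In this assay compound 4 gives only a limit, > 50000 nM, and this is not a number. The result adds a third kind of aryl at this aromatic nitrogen: 3,4-dichlorophenyl, which has no hydrogen-bond donors or acceptors, meets the same limit as the 4-ethoxyphenyl and 4-acetamidophenyl groups, so 3-sulfamoylphenyl remains the only group shown here with a measured value. Even so, the swap gives an at least 1.1-fold higher number from compound 3 to compound 4 (0.07 log units; that floor lies within the scatter), so compound 3 is not shown to differ from compound 4, and the steps among compound 1, compound 2 and compound 4 cannot be read, because all three sit at one limit: the limit of > 50000 nM in this assay, at which 3 of the 4 values shown sit.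

The compounds shown leave open whether any aryl at this nitrogen can bring the shared core clearly into the measurable range of this assay, for instance one carrying an amine or a carboxylic acid. They also leave open whether the sulfamoyl group of compound 3 matters at all, which a comparison with a plain phenyl or a 4-sulfamoylphenyl group could begin to address.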